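A few compounds are considered here, and "the series" means these few. Any claim that something is new, unique, unknown or untested is made for them only; others in the source may bear on it.

Measured so far in a functional assay on HeLa cells (Homo sapiens) for antiproliferative activity, read by MTT assay, with a stated time of 24 h; on this read-out lower numbers stand for stronger inhibition and higher numbers for weaker inhibition:
- compound 1 `Cc1ccc(-c2nn(-c3ccccc3)cc2-c2nc3ccccc3n2S(=O)(=O)c2cc(C)ccc2C)cc1`: 370 nM
- compound 2 `Cc1ccc(C)c(S(=O)(=O)n2c(-c3cn(-c4ccccc4)nc3-c3ccc(F)cc3)nc3ccccc32)c1`: 320 nM
- compound 3 `O=S(=O)(c1ccccc1)n1c(-c2cn(-c3ccccc3)nc2-c2ccc(C(F)(F)F)cc2)nc2ccccc21`: 560 nM

In this assay, compound 3 gives 560 nM, a value within the usual scatter of both other compounds. The next compound to consider is compound 4 `Cc1ccc(C)c(S(=O)(=O)n2c(-c3cn(-c4ccccc4)nc3-c3ccc(C(F)(F)F)cc3)nc3ccccc32)c1`. Going from compound 3 to compound 4, the phenylsulfonyl becomes (2,5-dimethylphenyl)sulfonyl: 2,5-dimethylphenyl in place of phenyl on a sulfonyl sulfur.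

Among the compounds with values here, no measured step covers this change on its own. Within the data shown here, the only measured step between compounds differing in one place is a 1.2-fold lower number from compound 1 to compound 2 (0.06 log units; within the scatter). It concerns a different change, fluoro in place of methyl on an aromatic carbon, and it stays within the scatter. It does show that compound 1 and compound 2, which both carry the (2,5-dimethylphenyl)sulfonyl, sit close together. Compound 1 gives 370 nM and compound 2 gives 320 nM. These values offer a rough guide, but they do not isolate the effect of the swap.

No step beyond the scatter is therefore expected in this assay, though a slightly lower number is the likelier direction. The expected change is a 1.3-fold lower number from compound 3 to compound 4 (0.12 log units; within the scatter). For compound 4 the estimated value is 420 nM, with an expected range from 220 nM to 800 nM.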

Compound 4, half-maximal inhibitory concentration: 210 nM
Compound 4: middle estimate off by 2.0-fold (0.30 log units), on the high side, and the stated range ends above it.
By their numbers in this assay, from the lowest: compounds 4, 2, 1 and 3 (each within the scatter of the next, the first and the last beyond it).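

In this assay, within the data shown here, changing the group on the sulfonyl sulfur gives a 2.7-fold lower number from compound 3 to compound 4 (0.43 log units; beyond the scatter), the first step here to pass beyond the scatter, so this position can shift the read-out, although a single pair is the only support for that so far. With the (2,5-dimethylphenyl)sulfonyl kept in place, changes on the aromatic carbon give much smaller steps: trifluoromethyl in place of fluoro gives a 1.5-fold lower number from compound 2 to compound 4 (0.18 log units; within the scatter), and trifluoromethyl in place of methyl gives a 1.8-fold lower number from compound 1 to compound 4 (0.25 log units; within the scatter), both within the scatter. Nothing available gives a reason for the step at the sulfonyl sulfur.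

The compounds shown leave open whether the same swap would give a similar step with fluoro or methyl in place of the trifluoromethyl, and whether both methyl groups of the 2,5-dimethylphenyl are needed. They also leave open how a phenyl carrying a methoxy group, a chlorine atom or an amine would behave on the same sulfonyl sulfur.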